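The source may hold more compounds than are shown below. What is called first, only, known or untested is meant among the compounds shown, and "the series" means these compounds.

Two measured members of the series share one core: compound 1 `Cc1cc(S(=O)(=O)/N=C(\N)n2nccc2-c2ccccc2)c(SCc2ccccc2C)cc1Cl` and compound 2 `Cc1cc(S(=O)(=O)/N=C(\N)n2nccc2-c2ccccc2)c(SCc2ccccc2Cl)cc1Cl`. In a functional assay on HeLa cells (Homo sapiens) for cytotoxicity, read by MTT assay, with a stated time of 72 h (a higher number here means a weaker inhibitor, a lower number a stronger inhibitor), compound 1 gives 17000 nM, and compound 2 gives 19000 nM. Of the two numbers shown, compound 2 is the higher one, but the gap to compound 1 lies within the scatter, so the two are not distinguished. Compound 3 `Cc1cc(S(=O)(=O)/N=C(\N)n2nccc2-c2ccccc2)c(SCc2ccccc2C(F)(F)F)cc1Cl` is not yet measured; it differs from compound 2 by trifluoromethyl in place of chloro on an aromatic carbon. For the measured compounds named here, one measured step bears on this change, a 1.1-fold higher number from compound 1 to compound 2 (0.05 log units; within the scatter), which also exchanged the group on an aromatic carbon of that ring and stayed within the scatter. No other comparison is available, and the second exchange is new. The expected step is no change at the digits printed from compound 2 to compound 3 (within the scatter), no change beyond the scatter, direction unresolved. The estimate for compound 3 is 19000 nM, with an expected range from 8000 nM to 45000 nM.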

Compound 3, half-maximal inhibitory concentration: 20000 nM
The estimate for compound 3 lay 1.1-fold (0.02 log units) below the measured number; the range from low to high includes it.
By their numbers in this assay, from the lowest: compounds 1, 2 and 3 (each within the scatter of the next).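

In this assay, trifluoromethyl in place of chloro gives a small step (a 1.1-fold higher number from compound 2 to compound 3 (0.02 log units; within the scatter)), and trifluoromethyl in place of methyl gives another (a 1.2-fold higher number from compound 1 to compound 3 (0.07 log units; within the scatter)). Where the earlier pair tested only one exchange on this aromatic carbon, methyl, chloro and trifluoromethyl now form a set of three groups that this read-out does not distinguish, even though the 2-(trifluoromethyl)benzyl group carries more heavy atoms than the 2-chlorobenzyl group. No measurement shown here accounts for this flat result.

From the compounds shown here alone, whether an amine, a carboxylic acid or a longer chain on this aromatic carbon would give a step beyond the scatter remains open. Also open, going by these compounds, is whether any of these groups would behave the same way on another carbon of that ring or with changes elsewhere in the shared core.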